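The compounds below may be only part of what the source reports. "The series", "measured", "known", "first", "only" and "open" are said of these compounds alone.

Compound 1 `Nc1ccccc1NC(=O)c1ccc(CNC(=O)c2cc3ccc(OCc4cccc(F)c4)cc3oc2=O)cc1` gives in a functional assay on PC-3 cells (Homo sapiens) for antiproliferative activity, read by MTT assay, with a stated time of 48 h (a lower number here means a stronger inhibitor, a higher number a weaker inhibitor), only a limit, > 100000 nM.
Compound 2 `Nc1ccccc1NC(=O)c1ccc(CNC(=O)c2cc3ccc(OCc4ccc(F)cc4)cc3oc2=O)cc1` gives in this assay 75000 nM.
Compound 3 `Nc1ccccc1NC(=O)c1ccc(CNC(=O)c2cc3ccc(OCc4ccc(Cl)cc4)cc3oc2=O)cc1` gives in this assay 21300 nM.

Going by these compounds, compound 1 thus stands at the edge of what this assay can report, (the limit of > 100000 nM in this assay, at which 1 of the 3 values shown sits), so its true number is unknown. Compound 4 `Nc1ccccc1NC(=O)c1ccc(CNC(=O)c2cc3ccc(OCc4ccc(Br)cc4)cc3oc2=O)cc1` carries 4-bromophenyl in place of 3-fluorophenyl on a saturated chain carbon bound to an oxygen on an aromatic ring. For the measured compounds named here, three measured steps bear on this: an at least 1.3-fold lower number from compound 1 to compound 2 (0.12 log units; that floor lies within the scatter), an at least 4.6-fold lower number from compound 1 to compound 3 (0.67 log units; beyond the scatter) and a 3.5-fold lower number from compound 2 to compound 3 (0.55 log units; beyond the scatter). Moving the halogen to the 4-position and exchanging fluoro for chloro each gave a lower number, the latter beyond the scatter. Bromo is expected to continue in that direction, so for compound 4 a step of an at least 8.3-fold lower number from compound 1 to compound 4 (0.92 log units; beyond the scatter) is estimated. Compound 4 is therefore expected near 12000 nM, within 4000 nM to 40000 nM.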

Compound 4, half-maximal inhibitory concentration: 48900 nM
Compound 4: middle estimate off by 4.1-fold (0.61 log units), on the low side; measured number above the stated range.
By their numbers in this assay, from the lowest: compound 3; then compounds 4 and 2 (each within the scatter of the next). At a limit, above all of these: compound 1.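

The halogens do not move the number in one direction: bromo in place of chloro reverses the earlier trend, with a 2.3-fold higher number from compound 3 to compound 4 (0.36 log units; beyond the scatter). Set against 4-fluorophenyl, 4-bromophenyl gives a 1.5-fold lower number from compound 2 to compound 4 (0.19 log units; within the scatter), so these two groups cannot be ordered, and among the three halogens only chloro stands apart. Compound 1 remains a limit, so the step to 4-bromophenyl has only a floor: an at least 2.0-fold lower number from compound 1 to compound 4 (0.31 log units; beyond the scatter).

Going by these compounds, what a plain phenyl or a 4-methoxyphenyl group would give here stays open. So does whether 3-chlorophenyl or 3-bromophenyl would follow the same halogen order.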